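This account rests on a few compounds, and the source may have more. Where it says the series, first, only, none or still open, it means among the compounds named here.

Measured in a functional assay on MDA-MB-231 cells (Homo sapiens) for antiproliferative activity, read by MTT assay, with a stated time of 48 h (on this read-out lower numbers stand for stronger inhibition and higher numbers for weaker inhibition), with compound 4 still open:
- compound 1 `CN1CCN(c2ccc(-c3cc4c(N5CCN(C(=O)Nc6ccc(Cl)cc6)CC5)ncnc4s3)cc2)CC1`: 5440 nM
- compound 2 `CN1CCN(c2ccc(-c3cc4c(N5CCN(C(=O)Nc6cccc(F)c6)CC5)ncnc4s3)cc2)CC1`: 13200 nM
- compound 3 `COc1ccccc1NC(=O)N1CCN(c2ncnc3sc(-c4ccc(N5CCN(C)CC5)cc4)cc23)CC1`: 23200 nM
- compound 4 `CN1CCN(c2ccc(-c3cc4c(N5CCN(C(=O)Nc6ccc(Cl)c(C(F)(F)F)c6)CC5)ncnc4s3)cc2)CC1`: not yet measured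

Compound 3 stands at 23200 nM. The measured steps reaching it are a 4.3-fold higher number from compound 1 to compound 3 (0.63 log units; beyond the scatter) and a 1.8-fold higher number from compound 2 to compound 3 (0.24 log units; within the scatter).

The next change is 4-chloro-3-(trifluoromethyl)phenyl in place of 2-methoxyphenyl on an amide-type nitrogen. The aryl group of compound 1 also carries chlorine, so the closest guide is a 4.3-fold higher number from compound 1 to compound 3 (0.63 log units; beyond the scatter), read in reverse. The other step at this place, a 2.4-fold higher number from compound 1 to compound 2 (0.38 log units; beyond the scatter), is also modest. Going by the values given here, no measured compound carries a trifluoromethyl group, so the guide is only partial.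

In this assay a modest move to a lower number is expected, and the expected step is a 4.6-fold lower number from compound 3 to compound 4 (0.67 log units; beyond the scatter). Compound 4 is estimated at 5000 nM, with an expected range of 1800 nM to 14000 nM.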

Compound 4, half-maximal inhibitory concentration: 2220 nM
Compound 4: middle estimate off by 2.3-fold (0.35 log units), on the high side; the measured number falls inside the stated range.
By their numbers in this assay, from the lowest: compound 4; then compound 1; then compounds 2 and 3 (each within the scatter of the next).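

In this assay, going by these compounds alone, the aryl group on the amide-type nitrogen covers a wider range than the earlier compounds showed, with the largest step so far (a 10-fold lower number from compound 3 to compound 4 (1.02 log units; beyond the scatter)) and a further clear one (a 5.9-fold lower number from compound 2 to compound 4 (0.77 log units; beyond the scatter)). Trifluoromethyl in place of hydrogen on an aromatic carbon of the 4-chlorophenyl group also lowers the number (a 2.5-fold lower number from compound 1 to compound 4 (0.39 log units; beyond the scatter)). No measured evidence bears on the reason for these steps.

On these data alone, it remains open whether 3-(trifluoromethyl)phenyl without the chlorine would give a similar number, and whether a nitrile in place of the trifluoromethyl would do the same.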